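Amide-nitrogen substituent variation on the shared core

This account rests on a few compounds, and the source may have more. Where it says the series, first, only, none or still open, it means among the compounds named here.

Compounds measured so far:
- compound 1, `CCn1c(C(=O)N[C@@H](C)C(=O)OC)ccc1C(CC)(CC)c1ccc(OCS(=O)(=O)c2ccccc2)c(C)c1`: 43700 nM
- compound 2, `CCn1c(C(=O)NCC(=O)OC)ccc1C(CC)(CC)c1ccc(OCS(=O)(=O)c2ccccc2)c(C)c1`: > 50000 nM (a limit)
- compound 3, `CCn1c(C(=O)NCCO)ccc1C(CC)(CC)c1ccc(OCS(=O)(=O)c2ccccc2)c(C)c1`: 15500 nM
- compound 4, `CCn1c(C(=O)N[C@@H](CO)CCCO)ccc1C(CC)(CC)c1ccc(OCS(=O)(=O)c2ccccc2)c(C)c1`: not yet measured

In a functional assay on MCF7 cells (Homo sapiens) for antiproliferative activity, read by MTT assay, with a stated time of 24 h (on this read-out lower numbers stand for stronger inhibition and higher numbers for weaker inhibition), compound 1 gives 43700 nM. For compound 2 the read-out is only a limit, > 50000 nM, so compound 2 stands at the weak end of the series (the limit of > 50000 nM in this assay, at which 1 of the 3 values shown sits). Compound 3 gives 15500 nM in this assay. Among the steps, an at least 1.1-fold higher number from compound 1 to compound 2 (0.05 log units; that floor lies within the scatter), a 2.8-fold lower number from compound 1 to compound 3 (0.45 log units; beyond the scatter) and an at least 3.2-fold lower number from compound 2 to compound 3 (0.50 log units; beyond the scatter).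

The step from compound 2 to compound 4 is a group of 7 heavy atoms (5 carbon, 2 oxygen; no ring) in place of a group of 5 heavy atoms (3 carbon, 2 oxygen; no ring), on an amide-type nitrogen.

Within the data shown here, two measured steps bear on it: an at least 3.2-fold lower number from compound 2 to compound 3 (0.50 log units; beyond the scatter), where a hydroxymethyl entered for a methoxycarbonyl, and a 2.8-fold lower number from compound 1 to compound 3 (0.45 log units; beyond the scatter), where a 2-hydroxyethyl entered for a 1-(methoxycarbonyl)ethyl. In both the number fell modestly when the ester was exchanged for a hydroxyl-bearing chain. Compound 4 likewise exchanges the ester for a chain with two hydrogen-bond donors, so a modest fall is expected in this assay, on the scale of an at least 2.7-fold lower number from compound 2 to compound 4 (0.44 log units; beyond the scatter). Compound 4 is estimated at 18000 nM, in the range 7000 nM to 50000 nM.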

Compound 4, half-maximal inhibitory concentration: 29600 nM
For compound 4 the middle estimate is 1.6-fold (0.22 log units) below the measured one, and the stated range covers the measured number.
By their numbers in this assay, from the lowest: compounds 3, 4 and 1 (each within the scatter of the next, the first and the last beyond it). At a limit, above all of these: compound 2.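

In this assay, adding a 3-hydroxypropyl to the chain of compound 3 gives a 1.9-fold higher number from compound 3 to compound 4 (0.28 log units; within the scatter), so this extra chain on the saturated carbon bound to the amide-type nitrogen produces no readable change. Set against the ester-bearing compound 1, the new substituent gives a 1.5-fold lower number from compound 1 to compound 4 (0.17 log units; within the scatter), which means that the exchange of ester for hydroxyl-bearing chain, readable for the 2-hydroxyethyl of compound 3, is not readable for compound 4, even though compound 4 has the larger group of the two. The step of an at least 1.6-fold lower number from compound 2 to compound 4 (0.22 log units; that floor lies within the scatter) has only a floor, set by a limit: the limit of > 50000 nM in this assay, at which 1 of the 4 values shown sits.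

Still open, on these data alone, is whether a carboxylic acid or an amine in place of the hydroxyl groups, or a longer chain than the 3-hydroxypropyl, would move the number in this assay beyond the scatter from compound 3. Also open, as far as these compounds go, are the effect of the opposite configuration at the stereocentre of compound 4 and whether either of its two hydroxyl groups alone accounts for its reading.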